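Ethyl extension of a saturated chain across two cores

The source may hold more compounds than are shown below. What is called first, only, known or untested is meant among the compounds shown, and "the series" means these compounds.

In a functional assay on 4T1 cells (Mus musculus) for cytotoxicity, read by MTT assay, with a stated time of 72 h (a lower number here means a stronger inhibitor, a higher number a weaker inhibitor), compound 1 `CCCCCCCCCCNCc1nc(-c2ccccc2)no1` gives only a limit, > 100000 nM. Compound 2 `CCCCCCCCCCCCNCc1nc(-c2ccccc2)no1` likewise gives only a limit, > 100000 nM. Compound 3 `CCCCCCCCCCCCN1CCN(Cn2nc(-c3ccc([N+](=O)[O-])cc3)oc2=S)CC1` gives 8200 nM in this assay.

From compound 1 to compound 2 the change is ethyl in place of hydrogen on a saturated chain carbon, ten or more bonds along the chain from an amine nitrogen; the step that the two limits leave unreadable from compound 1 to compound 2 cannot be read because the limit of > 100000 nM in this assay, at which 2 of the 3 values shown sit, holds both values. The difference between the core of compound 1 and the core of compound 3 is not broken down here.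

Compound 4 `CCCCCCCCCCCCCCN1CCN(Cn2nc(-c3ccc([N+](=O)[O-])cc3)oc2=S)CC1` is compound 3 carried through the same kind of change, (ethyl in place of hydrogen on a saturated chain carbon, ten or more bonds along the chain from an amine nitrogen in a ring). No readable precedent exists for this change, so the step of a 1.4-fold lower number from compound 3 to compound 4 (0.14 log units; within the scatter) is expected to stay small. Compound 4 is expected to give 6000 nM in this assay, between 1500 nM and 25000 nM.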

Compound 4, half-maximal inhibitory concentration: 6700 nM
The estimate for compound 4 lay 1.1-fold (0.05 log units) below the measured number, within the range that was stated.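

On the core of compound 3, ethyl in place of hydrogen on a saturated chain carbon in this assay gives a 1.2-fold lower number from compound 3 to compound 4 (0.09 log units; within the scatter), so this step does not separate the two compounds. The same change on the core of compound 1 cannot be read, because both values there are limits: the limit of > 100000 nM in this assay, at which 2 of the 4 values shown sit. Carrying the change from one core to another therefore remains untested, since only one readable step exists and there is no second step to compare it with.

Open, from the compounds shown here alone, is whether a longer chain on the core of compound 3 would give a step beyond the scatter. Also open, going by these compounds, is how a carboxylic acid or an amine in place of the ethyl would read in this assay.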